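The source may hold more compounds than are shown below. What is called first, only, known or untested is meant among the compounds shown, and "the series" means these compounds.

Compound 1 `O=C(Nc1ccccc1C(F)(F)F)C1CCc2ccccc2N1C(=O)c1ccccc1` is the parent of this small set. In a functional assay on MDA-MB-231 cells (Homo sapiens) for cytotoxicity, read by sulforhodamine B assay, with a stated time of 72 h (a higher number here means a weaker inhibitor of growth, a lower number a stronger inhibitor of growth), compound 1 gives 5290 nM. Compound 2 `O=C(Nc1ccccc1C(F)(F)F)C1CCc2ccccc2N1C(=O)c1ccc(Cl)cc1` carries a single change, (chloro in place of hydrogen on an aromatic carbon), and in this assay compound 2 gives 533 nM, a step of a 9.9-fold lower number from compound 1 to compound 2 (1.00 log units; beyond the scatter). Compound 3 `O=C(Nc1cc(C(F)(F)F)cc(C(F)(F)F)c1)C1CCc2ccccc2N1C(=O)c1ccccc1` rests on a different core; the difference between the two cores is not broken down here. In this assay compound 3 gives 2430 nM, a higher number than compound 2 shows and a lower number than compound 1 shows. Compound 4 `O=C(Nc1cc(C(F)(F)F)cc(C(F)(F)F)c1)C1CCc2ccccc2N1C(=O)c1cccc(Cl)c1` has not yet been measured. It differs from compound 3 by chloro in place of hydrogen on an aromatic carbon. This is the same kind of change as that from compound 1 to compound 2, though not the same: there the chloro sits para to a large group, here meta to a large group. For the measured compounds named here, compound 4 is expected to show a lower number than compound 3 because a 9.9-fold lower number from compound 1 to compound 2 (1.00 log units; beyond the scatter) was seen in the one earlier example. The step is expected to be a 3.7-fold lower number from compound 3 to compound 4 (0.57 log units; beyond the scatter). Its smaller size reflects the different place of the chloro. In this assay compound 4 is accordingly estimated at 650 nM, between 200 nM and 2000 nM.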

Compound 4, concentration for 50% growth inhibition: 1190 nM
Beside the measured number, compound 4's estimate is 1.8-fold (0.26 log units) below it; low and high end bracket the measured number.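

In this assay, chloro in place of hydrogen on the benzoyl ring gives a 2.0-fold lower number from compound 3 to compound 4 (0.31 log units; beyond the scatter), so the direction of the earlier step recurs on a second core. The size of the step does not carry over, and the two steps differ by more than the usual scatter: the same change on two cores in this assay, a 9.9-fold lower number (1.00 log units; beyond the scatter) from compound 1 to compound 2 and a 2.0-fold lower number (0.31 log units; beyond the scatter) from compound 3 to compound 4, 4.9-fold (0.69 log units) apart, beyond the scatter of two such steps This does not show that the core alone sets the size of the step, since the chloro also stands in a different place on the ring in compound 2 and in compound 4, and two pairs cannot separate these two differences.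

The compounds shown leave open what each core would give with the chloro moved to the place it holds on the other core, which is the comparison that would tell core and place apart. They also leave open whether the lower number is particular to chloro, or would also appear with fluoro, bromo, a methoxy group or a nitrile on the same ring.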